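One ring group exchanged on compound 1

A few compounds are considered here, and "the series" means these few. Any claim that something is new, unique, unknown or untested is made for them only; others in the source may bear on it.

Measured in an ADME assay on cells (Hepatocyte, Homo sapiens) for metabolic stability; a higher number here means that the compound lasts longer, a lower number that the compound disappears faster
- compound 1 `N#Cc1ccc(N2CCC(C(=O)N3N=CC[C@H]3c3cc(F)cc(F)c3)CC2)nn1` gives > 8 h
- compound 2 `CC(C)(C)C(=O)N1CCC1c1ccccc1` gives > 2.75 h

Compound 1 stands at > 8 h, which is a limit and not an exact number. Compound 2 also has only a limit, > 2.75 h. Among the measured compounds shown here, neither compound therefore has an exact reading, and no measured pair shows what a single structural change does here.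

Compound 3 `Cc1nnc(N2CCC(C(=O)N3N=CC[C@H]3c3cc(F)cc(F)c3)CC2)o1` keeps the core of compound 1 and differs in one place (a group of 6 heavy atoms (3 carbon, 2 nitrogen, 1 oxygen; one five-membered aromatic ring with 3 hetero atoms) in place of a group of 8 heavy atoms (5 carbon, 3 nitrogen; one six-membered aromatic ring with 2 hetero atoms), on an amine nitrogen in a ring). The 5-methyl-1,3,4-oxadiazol-2-yl group takes the place of a larger group with a six-membered aromatic ring, on an amine nitrogen in a ring.

Compound 1 is the only close relative, so its limit of > 8 h is the sole anchor for an expectation. In this assay the expected step of an at least 1.1-fold lower number from compound 1 to compound 3 (0.05 log units; that floor lies within the scatter) is a small fall, no larger than the usual scatter. This is a cautious expectation, and compound 3 may also come back as a limit rather than a number. For compound 3 the estimated half-life is 7 h, with an expected range from 3.5 h to 14 h.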

Compound 3, half-life: 3.3 h
For compound 3 the middle estimate is 2.1-fold (0.33 log units) above the measured one; the measured number lies below the stated range.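

In this assay, among the compounds shown here, the group on the amine nitrogen in the six-membered non-aromatic ring proves able to shift the result, which no earlier measured pair could show. With the rest of the core of compound 1 unchanged, placing the 5-methyl-1,3,4-oxadiazol-2-yl group where the six-membered aromatic ring with 2 hetero atoms stood gives an at least 2.4-fold lower number from compound 1 to compound 3 (0.38 log units; beyond the scatter). The true step may be larger than this floor, because compound 1 has only a limit and not an exact number: the limit of > 8 h in this assay, at which 1 of the 3 values shown sits.

Since the ring size, the hetero atoms, the triple bond outside the ring and the methyl group all change together in this single exchange, the compounds shown cannot tell which of these differences accounts for the shorter half-life, nor how long compound 1 actually lasts. A pyridine ring carrying the same nitrile, or an unsubstituted 1,3,4-oxadiazole on the same nitrogen, would separate some of these differences, and the compounds shown say nothing about how either would behave in this assay.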